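The compounds below may be only part of what the source reports. "The series", "measured", "known", "first", "only" and "open" are said of these compounds alone.

Working notes on the hydrazone series.

The series shares a core in which a naphthyl-bearing hydroxyalkyl amidrazone is linked to an aromatic aldehyde. Compound 1 `CCOc1cc(/C=N/N=C(\N)CC(O)c2ccc3ccccc3c2)ccc1O` carries the naphthalene through its second position and the 4-hydroxy-3-ethoxyphenyl aldehyde part; in an ADME assay on L6 cells (Rattus norvegicus) for cytotoxicity, read by resazurin assay, with a stated time of 72 h (a lower number here means a stronger inhibitor, a higher number a weaker inhibitor), compound 1 gives 78000 nM. Compound 2 `CCOc1cc(/C=N/N=C(\N)CC(O)c2cccc3ccccc23)ccc1O` keeps that aldehyde part but attaches the naphthalene through its first position; in this assay compound 2 gives 4200 nM. Compound 3 `N/C(CC(O)c1ccc2ccccc2c1)=N\N=C\c1cccnc1` keeps the naphthalene attachment of compound 1 and carries a pyridin-3-yl group on the carbon with a double bond to nitrogen. For compound 3 the entry in this assay reads "not determined" (no result reported), so it stands without a number and cannot be placed against compound 1 or compound 2.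

Compound 4 `COc1ccc(/C=N/N=C(\N)CC(O)c2ccc3ccccc3c2)cc1` is the next member and has not been measured. It differs from compound 3 as follows: 4-methoxyphenyl in place of pyridin-3-yl on a carbon with a double bond to nitrogen. For the measured compounds named here, no measured pair shows this change, so no step size can be read for it in this assay; the expectation is a step of no more than the usual scatter in either direction, with compound 1 as the nearest measured reference.

Compound 4 is expected to give about 50000 nM in this assay, within a range from 10000 nM to 200000 nM.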

Compound 4, half-maximal inhibitory concentration: 69000 nM
For compound 4 the middle estimate is 1.4-fold (0.14 log units) below the measured one; the measured number falls inside the stated range.
By their numbers in this assay, from the lowest: compound 2; then compounds 4 and 1 (each within the scatter of the next).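

In this assay no new step can be read from compound 3 to compound 4, as compound 3 stands without a number. The compounds shown leave open what replacing pyridin-3-yl with 4-methoxyphenyl does in this assay on this core. No supporting data bear on this result.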